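Oxime Ethers Against a Mouse Target: Adding a Second Chloro

The source may report more compounds than this note shows. Statements on the series, on what has been measured and on what is new or still open speak of the compounds shown alone.

Compound 1, `COc1ccc(C(/C=C/c2ccc(Cl)cc2)=N/O)cc1`: 11500 nM
Compound 2, `O/N=C(\C=C\c1ccc(Cl)cc1)c1ccc(Cl)cc1`: 9150 nM
Compound 3, `O/N=C(\C=C\c1ccc(Cl)cc1)c1ccc(Br)cc1`: 14700 nM

In a functional assay (Mus musculus, strain Balb/c) for inhibition, read by ELISA, with a stated time of 72 h (a lower number here means a stronger inhibitor, a higher number a weaker inhibitor), the three measured compounds lie close together. For the measured compounds named here, compound 3 gives the highest number of the three, but its gaps to the others, a 1.3-fold higher number from compound 1 to compound 3 (0.11 log units; within the scatter) and a 1.6-fold higher number from compound 2 to compound 3 (0.21 log units; within the scatter), both stay within the scatter, so no compound can be called stronger or weaker than another here.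

Compound 4, `O/N=C(\C=C\c1ccc(Cl)c(Cl)c1)c1ccc(Br)cc1`, differs from compound 3 by chloro in place of hydrogen on an aromatic carbon. Going by the values given here, this change sits on the other aromatic ring, where none of the measured steps act; the steps seen, such as a 1.3-fold lower number from compound 1 to compound 2 (0.10 log units; within the scatter), only swap groups on the ring bearing the bromo group, and all stay within the scatter. Among the compounds with values here, no step therefore speaks directly to the new chloro group, and no change beyond the scatter is expected.

Compound 4 is thus estimated at 12000 nM in this assay, ranging from 5000 nM to 30000 nM, a step of a 1.2-fold lower number from compound 3 to compound 4 (0.09 log units; within the scatter) from compound 3.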

Compound 4, half-maximal inhibitory concentration: < 5000 nM
Compound 4: a limit, no number; the forecaster's own chance of this, stated with the estimate: 10%; at least 2.4-fold (0.38 log units) between middle value and limit.
By their numbers in this assay, from the lowest: compounds 2, 1 and 3 (each within the scatter of the next). At a limit, below all of these: compound 4.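

In this assay, for the compounds shown here, chloro in place of hydrogen, ortho to a chloro group, gives the first step here that lies beyond the scatter: an at least 2.9-fold lower number from compound 3 to compound 4 (0.46 log units; beyond the scatter). The swaps among methoxy, chloro and bromo linking compound 1, compound 2 and compound 3 all stayed within the scatter, so this position responds where those changes did not. The reading for compound 4 is a limit of the assay, not a number: the limit of < 5000 nM in this assay, at which 1 of the 4 values shown sits.

From the compounds shown here alone, how far the number truly falls remains open. So does whether an amine or a carboxylic acid at this position would give a similar step.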